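A few compounds are considered here, and "the series" means these few. Any claim that something is new, unique, unknown or untested is made for them only; others in the source may bear on it.

Measured in a functional assay on NUGC-3 cells (Homo sapiens) for inhibition, read by sulforhodamine B assay, with a stated time of 48 h; on this read-out lower numbers stand for stronger inhibition of growth and higher numbers for weaker inhibition of growth:

compound 1, `O=C(Nc1cc(C(F)(F)F)cc(C(F)(F)F)c1)C1NCCc2ccccc21`, gives > 10000 nM, which is a limit of the assay rather than a number.
compound 2, `O=C(Nc1cccc(O)c1)C1c2ccccc2CCN1C(=O)c1ccc(Cl)cc1`, gives > 10000 nM, again a limit of the assay.
compound 3, `O=C(Nc1cccc(O)c1)C1NCCc2ccccc21`, gives > 10000 nM, also a limit of the assay.

All three values therefore sit at the limit of > 10000 nM in this assay, at which 3 of the 3 values shown sit, and none of them is a measured number. Among the measured compounds shown here, the one pair that differs in a single place is compound 3 and compound 2: the change is (4-chlorophenyl)carbonyl in place of hydrogen on an amine nitrogen in a ring, and the step it made is a step that the two limits leave unreadable from compound 3 to compound 2. The difference between the core of compound 1 and the core of compound 3 is not broken down here.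

Compound 4, `O=C(Nc1cc(C(F)(F)F)cc(C(F)(F)F)c1)C1c2ccccc2CCN1C(=O)c1ccc(Cl)cc1`, has not yet been measured in this assay. It arises from compound 1 by (4-chlorophenyl)carbonyl in place of hydrogen on an amine nitrogen in a ring, the same change as that from compound 3 to compound 2. For the measured compounds named here, because the only measured instance of this change is a step that both limits leave unreadable, and because compound 1 itself sits at the limit of > 10000 nM in this assay, at which 3 of the 3 values shown sit, there is no measured number from which the value of compound 4 could be read; the expectation rests on the three limits alone.

On that footing compound 4 is expected to give about 15000 nM in this assay, most likely between 3000 nM and 60000 nM. The expected step from compound 1 to compound 4 is a step that the limit leaves unreadable from compound 1 to compound 4, which is to say that compound 4 is expected to remain near the limit of the assay.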

Compound 4, concentration for 50% growth inhibition: 2830 nM
The estimate for compound 4 lay 5.3-fold (0.72 log units) above the measured number, and the stated range ends above it.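

Carried onto the amide that bears the trifluoromethyl groups, (4-chlorophenyl)carbonyl in place of hydrogen on the amine nitrogen in a ring gave, in this assay, an at least 3.5-fold lower number from compound 1 to compound 4 (0.54 log units; beyond the scatter), so on this core the change lowered the number by more than the usual scatter. Among the compounds shown here, compound 3 and compound 2, the only other pair with this change, both sit at a limit of the assay, so their step cannot be read, and the data neither confirm nor exclude that the change works on the hydroxyphenyl amide as well. The result therefore shows the change acting on one core only, not that it carries from one core to another, and even there its full size remains unknown, the reading resting on one pair with a limit as its starting point: the limit of > 10000 nM in this assay, at which 3 of the 4 values shown sit.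

The compounds shown leave open whether a simpler acyl group such as acetyl, or a benzoyl group without the chlorine, would lower the number in the same way on the same ring nitrogen. They also leave open how the change would behave on an amide carrying a carboxylic acid or an amine on its phenyl ring.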